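From Methanesulfonamido to Acetoxy: Expected Microsomal Stability

The source may hold more compounds than are shown below. What is called first, only, known or untested is meant among the compounds shown, and "the series" means these compounds.

Compound 1 `COc1cc(-c2c(C)nc3c(N4CC[C@@H](NC(C)=O)C4)cc(C)nn23)ccc1F` and compound 2 `COc1ccc(-c2c(C)nc3c(N4CC[C@@H](NS(C)(=O)=O)C4)cc(C)nn23)cc1OC` have both been tested in an ADME assay on microsomes from liver (Mus musculus) for metabolic stability, read by LC-MS, with NADPH named in the record, with a stated time of 60 min, tested at 1 uM, in the absence of a further agent; on this read-out lower numbers stand for a less stable compound and higher numbers for a more stable compound. In that assay compound 1 gives > 95%, which is a limit of the assay rather than a number. Compound 2 likewise gives > 95%, again a limit and not a measured number. On the numbers shown, compound 2 therefore stands at the top of what this assay can report, alongside compound 1, as the limit of > 95% in this assay, at which 2 of the 2 values shown sit, records; no measured step between these two compounds is given, so only their two values can be stated. Compound 3 `COc1ccc(-c2c(C)nc3c(N4CC[C@@H](OC(C)=O)C4)cc(C)nn23)cc1OC` has not yet been measured. It differs from compound 2 in one place: acetoxy in place of methanesulfonamido on a saturated ring carbon. Among the compounds with values here, with no measured step of this kind to lean on, the step of a number at least 15 percentage points lower from compound 2 to compound 3 (beyond the scatter) is expected to be a modest fall beyond the usual scatter. Compound 3 is estimated to give 80% in this assay, within a range from 50% to 95%.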

Compound 3, percent of the compound remaining: > 95%
Compound 3: only a limit was reported; the forecaster's own chance of this, stated with the estimate: 35%; middle value at least 15 percentage points from the limit.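

No step can be read from compound 2 to compound 3 in this assay, since both results are limits of the assay rather than numbers: the limit of > 95% in this assay, at which 3 of the 3 values shown sit.

As far as these compounds go, whether acetoxy and methanesulfonamido differ at all on this read-out stays open, and so does which change would bring a compound within readable range.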